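Fluoro in Place of Trifluoromethyl on Compound 2

A few compounds are considered here, and "the series" means these few. Any claim that something is new, unique, unknown or untested is made for them only; others in the source may bear on it.

Compound 2 `O=S(=O)(Nc1ccc(-c2nc3ccccc3o2)cc1)c1ccccc1C(F)(F)F` carries a trifluoromethyl on an aromatic carbon of the ring bound to the sulfonyl sulfur. In an assay on isolated protein for inhibition of malate dehydrogenase, mitochondrial (Sus scrofa), with stated times of 45 min and 30 min (on this read-out lower numbers stand for stronger inhibition and higher numbers for weaker inhibition), compound 2 gives only a limit, > 63000 nM, and no number. Compound 1 `O=S(=O)(Nc1ccc2oc(-c3ccccc3)nc2c1)c1ccc(Cl)c(Cl)c1` likewise gives in this assay only a limit, > 63000 nM. Compound 3 `CS(=O)(=O)Nc1ccc2oc(-c3ccccc3)nc2c1`, with methyl in place of 3,4-dichlorophenyl on a sulfonyl sulfur, also gives only a limit, > 63000 nM. For the measured compounds named here, the step that the two limits leave unreadable from compound 1 to compound 3 is therefore not readable in size, and the limit of > 63000 nM in this assay, at which 3 of the 3 values shown sit, shows that every value so far sits at that limit. Compound 4 `O=S(=O)(Nc1ccc(-c2nc3ccccc3o2)cc1)c1ccccc1F` differs from compound 2 by fluoro in place of trifluoromethyl on an aromatic carbon. Going by the values given here, no measured step touches this position, and no measured value gives a number from which a change could be anchored. The chemist therefore expects no step beyond the scatter; the step that the limit leaves unreadable from compound 2 to compound 4 is his estimate. For compound 4 he estimates 150000 nM in this assay, within 40000 nM to 600000 nM, with a strong chance that only a limit is again reported.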

Compound 4, half-maximal inhibitory concentration: > 63000 nM
Compound 4: only a limit was reported (the forecaster's own chance of this, stated with the estimate: 85%); the middle value does not contradict the limit.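

For the compounds shown here, compound 2 and compound 4 each give only a limit, so no step between them can be read: the limit of > 63000 nM in this assay, at which 4 of the 4 values shown sit. The compounds shown leave open how strongly any of them inhibits the enzyme, and whether fluoro and trifluoromethyl differ in their effect on that inhibition.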